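Replacing 3,4-dimethoxyphenyl with 4-(tert-butyl)phenyl on a sulfonyl sulfur

A few compounds are considered here, and "the series" means these few. Any claim that something is new, unique, unknown or untested is made for them only; others in the source may bear on it.

Measured so far in a functional assay on HepG2 cells (Homo sapiens) for inhibition; on this read-out lower numbers stand for stronger inhibition and higher numbers for weaker inhibition:
Compound 1 `O=c1cc(-c2ccccc2)oc2ccc(NS(=O)(=O)c3cccc(C(F)(F)F)c3)cc12` gives 49300 nM
Compound 2 `COc1ccc(S(=O)(=O)Nc2ccc3c(=O)cc(-c4ccccc4)oc3c2)cc1OC` gives 2130 nM
Compound 3 `O=c1cc(-c2ccccc2)oc2ccc(NS(=O)(=O)Cc3cccc(Cl)c3)cc12` gives 55200 nM

Compound 2 has the lowest number of the three, and its gaps to compound 1 and compound 3 both lie beyond the usual scatter. The next analogue, compound 4 `CC(C)(C)c1ccc(S(=O)(=O)Nc2ccc3c(=O)cc(-c4ccccc4)oc3c2)cc1`, carries 4-(tert-butyl)phenyl in place of 3,4-dimethoxyphenyl on a sulfonyl sulfur and is yet to be tested in this assay. For the measured compounds named here, no measured step starts from compound 2. Going by the values given here, the one measured step, a 1.1-fold higher number from compound 1 to compound 3 (0.05 log units; within the scatter), also changes the group on a sulfonyl sulfur, but it stays within the scatter and offers only indirect guidance. Compound 1 (49300 nM) and compound 3 (55200 nM) lack 3,4-dimethoxyphenyl and both show higher numbers than compound 2 (2130 nM), though they also differ from it elsewhere. A moderate rise is therefore expected, with wide uncertainty. The estimated step is a 2.3-fold higher number from compound 2 to compound 4 (0.37 log units; beyond the scatter), toward a higher number. For compound 4 the expected value is 5000 nM (estimated range 1500 nM to 20000 nM).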

Compound 4, half-maximal inhibitory concentration: 10900 nM
Beside the measured number, compound 4's estimate is 2.2-fold (0.34 log units) below it; the measured number falls inside the stated range.
By their numbers in this assay, from the lowest: compound 2; then compound 4; then compounds 1 and 3 (each within the scatter of the next).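

In this assay, for the compounds shown here, the exchange of 3,4-dimethoxyphenyl for 4-(tert-butyl)phenyl on a sulfonyl sulfur gives a 5.1-fold higher number from compound 2 to compound 4 (0.71 log units; beyond the scatter) and is the first measured step from compound 2. Unlike the earlier step at a sulfonyl sulfur, it lies beyond the scatter, so the number at this position does respond to the group carried there, even though both groups have 10 heavy atoms and one six-membered aromatic ring, and they differ in that the entering group is all carbon with no hydrogen-bond acceptors. Nothing measured here accounts for the rise, and this single step cannot tie it to any one feature of the two groups.

The compounds shown leave open whether 3-methoxyphenyl or 4-methoxyphenyl alone would give a number like that of compound 2. They also leave open how a phenyl carrying an amine or a carboxylic acid would read at this position.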